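Chloro in place of methoxy: compound 1 to compound 4

A few compounds are considered here, and "the series" means these few. Any claim that something is new, unique, unknown or untested is made for them only; others in the source may bear on it.

Measured in a functional assay on HCT-116 cells (Homo sapiens) for antiproliferative activity, with a stated time of 48 h; on this read-out higher numbers stand for weaker inhibition and lower numbers for stronger inhibition:
compound 1 `CCN(CC)c1ccc(-c2cccc(OC)c2)nn1`: > 25000 nM (a limit)
compound 2 `CC(=O)c1ccc(-c2ccc(N3CCCC3)nn2)cc1`: > 25000 nM (a limit)
compound 3 `COc1ccc(Nc2ccc(-c3ccccc3)nn2)cc1`: > 25000 nM (a limit)

The three measured compounds give no number to compare, only (the limit of > 25000 nM in this assay, at which 3 of the 3 values shown sit). In this assay compound 1 gives > 25000 nM, which is a limit of the assay and not a number. For the measured compounds named here, no measured step between compounds that differ in one place is available, so the series offers no direct guide to the size of this change.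

Compound 4 `CCN(CC)c1ccc(-c2cccc(Cl)c2)nn1` departs from compound 1 by chloro in place of methoxy on an aromatic carbon, meta to a large group. Going by these compounds, no step beyond the scatter is expected in this assay, and the direction remains open. The expectation rests on compound 1, with its limit of > 25000 nM, and on the same kind of limit for the two other measured compounds. The expected change is a number no higher from compound 1 to compound 4 (the limit leaves the size open). For compound 4 the estimated value is 25000 nM, with an expected range from 10000 nM to 50000 nM.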

Compound 4, half-maximal inhibitory concentration: > 25000 nM
Compound 4: a limit, no number; the forecaster's own chance of this, stated with the estimate: 70%; the middle value sits exactly at the limit.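

Compound 1 and compound 4 both give a limit rather than a number in this assay, so no step can be read for chloro in place of methoxy: the limit of > 25000 nM in this assay, at which 4 of the 4 values shown sit.

The compounds shown leave open the size and direction of this change, and which structure would give a measurable value in this assay.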